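Stereo variants around compound 2: working notes

A few compounds are considered here, and "the series" means these few. Any claim that something is new, unique, unknown or untested is made for them only; others in the source may bear on it.

compound 1 `O=C1C[C@@H](O[C@H]2O[C@H](CO)[C@@H](O)[C@H](O)[C@H]2O)CN1Cc1ccccc1` gives 72500 nM in a functional assay on RAW264.7 cells (Mus musculus) for inhibition, read by Griess assay, with a stated time of 24 h; on this read-out lower numbers stand for stronger inhibition and higher numbers for weaker inhibition
compound 2 `O=C1C[C@H](O[C@H]2O[C@H](CO)[C@@H](O)[C@H](O)[C@H]2O)CN1Cc1ccccc1` gives 105000 nM in this assay

Compound 2 stands at the higher of the two numbers measured; its nearest neighbour is compound 1, and the step of a 1.4-fold higher number from compound 1 to compound 2 (0.16 log units; within the scatter) is within the scatter, the pair differing only in configuration (the fact that compounds 1 and 2 differ only in the configuration as drawn). Among the measured compounds shown here, compound 3 `O=C1C[C@@H](O[C@H]2O[C@H](CO)[C@@H](O)[C@H](O)[C@@H]2O)CN1Cc1ccccc1` is the next point. the two compounds have the same atoms and bonds and differ only in configuration as drawn: 2 of 6 stereo elements differ; a stereocentre at a saturated ring carbon is drawn S in compound 2 and R in compound 3; a stereocentre at a saturated ring carbon is drawn R in compound 2 and S in compound 3 The only measured step that bears on this is the single configurational change that gave a 1.4-fold higher number from compound 1 to compound 2 (0.16 log units; within the scatter), within the scatter. Nothing measured speaks to the second stereocentre that changes here. Because the step of a 1.4-fold higher number from compound 1 to compound 2 (0.16 log units; within the scatter) stayed within the scatter, no step beyond the scatter is expected for compound 3 either, in either direction. Compound 3 is therefore estimated at 80000 nM in this assay, with a range of 35000 nM to 180000 nM. The step expected is a 1.3-fold lower number from compound 2 to compound 3 (0.12 log units; within the scatter).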

Compound 3, half-maximal inhibitory concentration: 97200 nM
The estimate for compound 3 lay 1.2-fold (0.08 log units) below the measured number; low and high end bracket the measured number.
By their numbers in this assay, from the lowest: compounds 1, 3 and 2 (each within the scatter of the next).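

A second stereocentre at a saturated ring carbon now has a single-change step of its own in this assay: a 1.3-fold higher number from compound 1 to compound 3 (0.13 log units; within the scatter). Changing two stereocentres together gives a 1.1-fold lower number from compound 2 to compound 3 (0.03 log units; within the scatter), so the paired change shows no larger separation in this read-out than either single change: the fact that compounds 2 and 3 differ only in the configuration as drawn

Neither stereocentre varied among compounds 1, 2 and 3 is shown to move the number in this assay. From the compounds shown here alone, the other stereocentres of the shared core remain open, since all three compounds hold them as drawn. Also open, going by these compounds, is what a change of atoms rather than configuration would do, such as an amine or a carboxylic acid in place of the hydroxymethyl group.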